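The source may report more compounds than this note shows. Statements on the series, on what has been measured and on what is new or still open speak of the compounds shown alone.

Three compounds share one core. Compound 1 `CC(C)(C)Cc1csc(N)c1C(=O)c1ccc(Cl)cc1` in an assay on CHO cells for displacement of a labelled ligand from adenosine receptor A1 (Homo sapiens), read by scintillation counting, tested at 10 uM (a lower number here means less inhibition, a higher number more inhibition at the concentration tested (going by the name of the read-out)), gives 1%. Compound 2 `CC(C)(C)Cc1c(-c2cc(F)ccc2F)sc(N)c1C(=O)c1ccc(Cl)cc1` in this assay gives 3%, and compound 3 `Cc1ccc(C(=O)c2c(CC(C)(C)C)csc2N)cc1` in this assay gives 1%. Compound 3 thus stands level with compound 1, the two together holding the lowest of the three numbers, and the step of no change at the digits printed from compound 1 to compound 3 (within the scatter) shows that exchanging methyl for chloro on an aromatic carbon left the read-out where it was. Within the data shown here, the only other measured step, a number 2 percentage points higher from compound 1 to compound 2 (within the scatter), added an aromatic ring to the core and likewise stayed within the scatter.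

Compound 4 `Cc1ccc(C(=O)c2c(N)sc(-c3ccccc3)c2CC(C)(C)C)cc1` has not yet been measured in this assay. It differs from compound 3 by phenyl in place of hydrogen on an aromatic carbon. The step that bears on this change is a number 2 percentage points higher from compound 1 to compound 2 (within the scatter), which also brought an aromatic ring onto the core and was small. Compound 4 is therefore expected to show no step beyond the scatter, a number 2 percentage points higher from compound 3 to compound 4 (within the scatter). The value expected for compound 4 in this assay is 3%, with a range from 0% to 12%.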

Compound 4, a percentage reported as inhibition, at one concentration (the size of the read-out at that concentration, not a potency): 1%
Compound 4: middle estimate off by 2 percentage points, on the high side; the range from low to high includes it.
By their numbers in this assay, from the lowest: compounds 1, 3, 4 and 2 (each within the scatter of the next).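

With phenyl in place of hydrogen on the aromatic carbon next to the ring sulfur, the compounds show no change at the digits printed from compound 3 to compound 4 (within the scatter) in this assay and so give a second reading of an aromatic ring at this position. The earlier ring step carried a 2,5-difluorophenyl on the compound with the chloro group, whereas this one carries an unsubstituted phenyl on the compound with the methyl group, and both steps stay within the scatter. No measurement offered here explains the flat reading.

The compounds leave open whether a group other than an aromatic ring at this position, such as an amine, a carboxylic acid or a longer alkyl chain, would move the read-out. They also leave open whether phenyl would behave the same way if the neopentyl group gave way to a shorter chain.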